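Methoxy in place of methyl on the core of compound 1

The source may report more compounds than this note shows. Statements on the series, on what has been measured and on what is new or still open speak of the compounds shown alone.

Compound 1 `Cc1ccc2c(=S)cc(-c3ccccc3)oc2c1` was examined in an in vitro assay on BTI-TN-5B1-4 cells for inhibition of Amine oxidase [flavin-containing] B (Homo sapiens), tested at 100 uM (a lower number here means less inhibition, a higher number more inhibition at the concentration tested (going by the name of the read-out)), where compound 1 gives 40%. Among the measured compounds shown here, its only measured neighbour is compound 2 `COc1ccc(-c2cc(=S)c3ccc(C)cc3o2)cc1`, which in this assay gives 40%; the step of no change at the digits printed from compound 1 to compound 2 (within the scatter) put a methoxy in place of hydrogen on an aromatic carbon and left the read-out where it was. For the measured compounds named here, compound 1 thus stands level with compound 2, and nothing measured so far separates the two.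

Compound 3 `COc1ccc2c(=S)cc(-c3ccccc3)oc2c1` has not yet been measured. It differs from compound 1 as follows: methoxy in place of methyl on an aromatic carbon. Going by the values given here, no measured step covers a methoxy entering in place of methyl on the fused two-ring system of the core; the one measured step, in which a methoxy entered elsewhere, was flat. Lacking a closer precedent, the step of a number 2 percentage points lower from compound 1 to compound 3 (within the scatter) is expected to stay within the scatter. Compound 3 is therefore estimated to give 38% in this assay, with a range from 20% to 58%.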

Compound 3, a percentage reported as inhibition, at one concentration (the size of the read-out at that concentration, not a potency): 40%
The estimate for compound 3 lay 2 percentage points below the measured number, within the range that was stated.
By their numbers in this assay, from the lowest: compounds 1, 2 and 3 (each within the scatter of the next).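

In this assay the exchange at this aromatic carbon of the core, methoxy in place of methyl, gave no change at the digits printed from compound 1 to compound 3 (within the scatter) and so showed that this place takes either group without a change in the read-out at the one concentration tested. Among the compounds shown here, the earlier step, no change at the digits printed from compound 1 to compound 2 (within the scatter), had put its methoxy elsewhere, so this is the first measured change on the core itself, and neither step has yet moved the number. Nothing measured here offers a reason for this flat result.

Going by these compounds, whether an amine, a carboxylic acid or a longer chain such as butoxy at this place would move the read-out beyond the scatter remains open. Since each number is a percentage at a single concentration, the potencies of these compounds also remain open.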